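This account rests on a few compounds, and the source may have more. Where it says the series, first, only, none or still open, it means among the compounds named here.

Series notes, antiproliferative read-out on the shared core. Among the measured compounds shown here, compound 1 `CCOc1ccc(-c2ccc3ncn(-c4cc(OC)c(OC)c(OC)c4)c3c2)cc1` is the reference here; in a functional assay on A549 cells (Homo sapiens) for antiproliferative activity, read by MTT assay, with a stated time of 72 h (on this read-out higher numbers stand for weaker inhibition and lower numbers for stronger inhibition), compound 1 gives 8550 nM, the highest of the three numbers so far. Compound 2 `COc1cc(-n2cnc3ccc(-c4ccc(C(C)=O)cc4)cc32)cc(OC)c1OC` gives 2510 nM and compound 3 `COc1cc(-n2cnc3ccc(-c4ccc(C)cc4)cc32)cc(OC)c1OC` gives 1940 nM. The two steps from compound 1 are both beyond the scatter: a 3.4-fold lower number from compound 1 to compound 2 (0.53 log units; beyond the scatter) and a 4.4-fold lower number from compound 1 to compound 3 (0.64 log units; beyond the scatter). Between compound 2 and compound 3 the step of a 1.3-fold lower number from compound 2 to compound 3 (0.11 log units; within the scatter) stays within the scatter, so nothing is read into their order.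

Compound 4 `COc1cc(-n2cnc3ccc(-c4ccc(Cl)cc4Cl)cc32)cc(OC)c1OC` has not yet been measured in this assay. The change from compound 1 is 2,4-dichlorophenyl in place of 4-ethoxyphenyl on an aromatic carbon. For the measured compounds named here, no measured step exchanges the whole aryl group in this way, so the nearest guides are the two steps that also alter the group carried at this position, from compound 1 to compound 2 and from compound 1 to compound 3, both of modest size and both toward lower numbers. On that basis a step of similar size in the same direction is expected, a 3.1-fold lower number from compound 1 to compound 4 (0.48 log units; beyond the scatter), though the range is kept wide because the entering group differs from both compound 2 and compound 3. Compound 4 is therefore estimated at 2800 nM, with a range from 900 nM to 9000 nM.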

Compound 4, half-maximal inhibitory concentration: > 10000 nM
Compound 4 was reported as a limit; the forecaster's own chance of this, stated with the estimate: 5%; middle value at least 3.5-fold (0.55 log units) away from the limit.
By their numbers in this assay, from the lowest: compounds 3 and 2 (each within the scatter of the next); then compound 1. At a limit, above all of these: compound 4.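

Compound 4 sits at a limit in this assay, not at a number: the limit of > 10000 nM in this assay, at which 1 of the 4 values shown sits. Exchange of the aryl group at this position does not always lower the number, as both earlier steps from compound 1 did, and 2,4-dichlorophenyl stands clearly apart from the other two groups that lowered it: an at least 5.1-fold higher number from compound 3 to compound 4 (0.71 log units; beyond the scatter), and an at least 3.9-fold higher number from compound 2 to compound 4 (0.60 log units; beyond the scatter). Against the reference the reading is only an at least 1.1-fold higher number from compound 1 to compound 4 (0.06 log units; that floor lies within the scatter), so the change is not shown to raise the number over 4-ethoxyphenyl; what it shows is that the drop seen with 4-methylphenyl and 4-acetylphenyl does not carry over to this group.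

Going by these compounds, how far compound 4 actually lies beyond the limit stays open, and with it the true size of all three steps. On these data alone, compound 4 alters the whole aryl group at once, so it remains open how a phenyl group carrying one chlorine would read, or one carrying an amine or a carboxylic acid in the place of the ethoxy group.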